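A Fluorine Added to the Benzamide Ring on Two Cores

The compounds below may be only part of what the source reports. "The series", "measured", "known", "first", "only" and "open" are said of these compounds alone.

Compound 1 `CCCCNC(=O)N1Cc2c(NC(=O)c3ccccc3)nn(C(=O)c3ccccc3)c2C1` and compound 2 `CCCCNC(=O)N1Cc2c(NC(=O)c3ccc(F)cc3)nn(C(=O)c3ccccc3)c2C1` share one core, while compound 3 `O=C(Nc1nn(C(=O)C2CC2)c2c1CN(C(=O)c1ccccc1)C2)c1ccccc1` and compound 4 `O=C(Nc1nn(C(=O)C2CC2)c2c1CN(C(=O)c1ccccc1)C2)c1ccc(F)cc1` share another; the difference between the two cores is not broken down here. In a functional assay on HCT-116 cells (Homo sapiens) for cytotoxicity, read by sulforhodamine B assay, with a stated time of 48 h (a higher number here means a weaker inhibitor, a lower number a stronger inhibitor), compound 1 gives 7470 nM, and compound 2 gives 30800 nM. The change that separates them is fluoro in place of hydrogen on an aromatic carbon, and it produced a 4.1-fold higher number from compound 1 to compound 2 (0.62 log units; beyond the scatter). In this assay compound 3 gives 1240 nM, the lowest of the three measured numbers. Compound 4 carries the same kind of change on the second core: fluoro in place of hydrogen on an aromatic carbon. The two descriptions of the place match word for word, so the surroundings of the new fluorine read the same in both pairs, and only the cores differ. Going by the values given here, only one earlier example of this change is available, and it sits on a different core; the expectation for compound 4 leans on that single step and allows for a wide range. The expected step is a 3.1-fold higher number from compound 3 to compound 4 (0.49 log units; beyond the scatter), resting on a 4.1-fold higher number from compound 1 to compound 2 (0.62 log units; beyond the scatter). Compound 4 is therefore estimated to give 3800 nM in this assay. Its expected range runs from 1500 nM to 10000 nM, reflecting the uncertainty of carrying one observation onto a new core.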

Compound 4, half-maximal inhibitory concentration: 2280 nM
For compound 4 the middle estimate is 1.7-fold (0.22 log units) above the measured one, within the range that was stated.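

On the second core, fluoro in place of hydrogen on an aromatic carbon gives a 1.8-fold higher number from compound 3 to compound 4 (0.26 log units; within the scatter), so in this assay compound 3 and compound 4 cannot be told apart. Set beside the step on the first core, this result does not stand apart from the earlier one: the same change on two cores in this assay, a 4.1-fold higher number (0.62 log units; beyond the scatter) from compound 1 to compound 2 and a 1.8-fold higher number (0.26 log units; within the scatter) from compound 3 to compound 4, 2.2-fold (0.35 log units) apart, within the scatter of two such steps. The two pairs therefore fit the idea that this change carries from one core to the other with a similar size, but they do not prove that the size is the same, since the step on the first core lies beyond the scatter while the step on the second lies within it, and two pairs are a thin basis for any rule about the series.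

The compounds shown leave open whether a chlorine atom, a methoxy group, an amine or a carboxylic acid in place of the fluorine would give steps that also match across the two cores. They also leave open what fluorine would do at other places on this ring, and what each part of the difference between the two cores contributes on its own.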